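A 3-hydroxyphenyl group becomes a 4-hydroxyphenyl group

This account rests on a few compounds, and the source may have more. Where it says the series, first, only, none or still open, it means among the compounds named here.

In a functional assay on HeLa cells (Homo sapiens) for cytotoxicity, read by ELISA, with a stated time of 2 days (a higher number here means a weaker inhibitor, a lower number a stronger inhibitor), compound 1 `Oc1cccc(-c2cc(-c3ccccc3)cc(-c3ccccc3)n2)c1` gives 16100 nM, compound 2 `Oc1cccc(-c2cc(-c3ccccc3)cc(-c3cccs3)n2)c1` gives 17000 nM and compound 3 `Oc1cccc(-c2cc(-c3ccccc3)cc(-c3ccco3)n2)c1` gives 9430 nM. Compound 1 therefore stands within the scatter of both others. In compound 4 `Oc1ccc(-c2cc(-c3ccccc3)cc(-c3ccccc3)n2)cc1`, 4-hydroxyphenyl takes the place of 3-hydroxyphenyl on an aromatic carbon (4-hydroxyphenyl in place of 3-hydroxyphenyl on an aromatic carbon). The nearest guides are a 1.1-fold higher number from compound 1 to compound 2 (0.02 log units; within the scatter) and a 1.7-fold lower number from compound 1 to compound 3 (0.23 log units; within the scatter), both swaps of a phenyl group for another ring. Neither moves the hydroxyl, and no measurement here does, so the guide is loose. No step beyond the scatter is expected in this assay, and the expected step is a 1.2-fold lower number from compound 1 to compound 4 (0.06 log units; within the scatter). For compound 4 the estimated value is 14000 nM, with an expected range from 5000 nM to 38000 nM.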

Compound 4, half-maximal inhibitory concentration: 1700 nM
Compound 4: middle estimate off by 8.2-fold (0.92 log units), on the high side; the measured number lies below the stated range.
By their numbers in this assay, from the lowest: compound 4; then compounds 3, 1 and 2 (each within the scatter of the next).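

Moving the hydroxyl, with the same atoms kept, gives a 9.5-fold lower number from compound 1 to compound 4 (0.98 log units; beyond the scatter) in this assay. The earlier swaps of a phenyl group for another ring all stayed within the scatter, so this is the first change shown here that goes beyond it, and it shows that where the hydroxyl sits on this ring matters. No evidence at hand explains the shift. On these data alone, it remains open whether the step holds with furan-2-yl or thiophen-2-yl in place of a phenyl group, and whether an amine or a carboxylic acid could stand in for the hydroxyl of 4-hydroxyphenyl.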